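This account rests on a few compounds, and the source may have more. Where it says the series, first, only, none or still open, it means among the compounds named here.

Compound 3 `CCCN(Cc1ccc(C(=O)NO)cc1)c1ncc(-c2ccc(C)cc2)s1` gives the lowest number of the three measured compounds in a functional assay on HepG2 cells (Homo sapiens) for antiproliferative activity, read by MTT assay, with a stated time of 48 h (a higher number here means a weaker inhibitor of growth, a lower number a stronger inhibitor of growth), at 2550 nM. Compound 1 `Cc1ccc(-c2cnc(N(Cc3ccc(C(=O)NO)cc3)CC(C)C)s2)cc1` gives 7420 nM in this assay, and compound 2 `Cc1ccc(OCCCN(Cc2ccc(C(=O)NO)cc2)c2ncc(-c3ccc(C)cc3)s2)cc1` gives 12200 nM. Between the first two there is only a 1.6-fold higher number from compound 1 to compound 2 (0.22 log units; within the scatter). Compound 4 `Cc1ccc(-c2cnc(N(CCCCOc3ccccc3)Cc3ccc(C(=O)NO)cc3)s2)cc1` differs from compound 3 by phenoxymethyl in place of hydrogen on a saturated chain carbon, three bonds along the chain from a nitrogen on an aromatic ring. The step that bears most directly on this change is the one that removed a closely related group from the same place on the chain, namely a 4.8-fold lower number from compound 2 to compound 3 (0.68 log units; beyond the scatter); compound 4 essentially runs that change backwards. The shortening of the chain by one carbon in a 2.9-fold lower number from compound 1 to compound 3 (0.46 log units; beyond the scatter) points the same way, with a smaller chain going with a lower number. A step of comparable size in the opposite direction is therefore expected, a 3.9-fold higher number from compound 3 to compound 4 (0.59 log units; beyond the scatter). Compound 4 is estimated at 10000 nM in this assay, within a range from 4000 nM to 25000 nM.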

Compound 4, concentration for 50% growth inhibition: 16600 nM
Beside the measured number, compound 4's estimate is 1.7-fold (0.22 log units) below it; the range from low to high includes it.
By their numbers in this assay, from the lowest: compound 3; then compounds 1, 2 and 4 (each within the scatter of the next, the first and the last beyond it).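

Placing phenoxymethyl on this chain carbon gives the largest step so far at this position (a 6.5-fold higher number from compound 3 to compound 4 (0.81 log units; beyond the scatter)) in this assay, so propyl stands clearly apart from the chain in compound 4. Exchanging 4-methylphenoxy for phenoxymethyl at the same carbon stays within the scatter (a 1.4-fold higher number from compound 2 to compound 4 (0.13 log units; within the scatter)), so compound 2 and compound 4 cannot be told apart, although both remain beyond the scatter from compound 3. Unlike 2-(4-methylphenoxy)ethyl, 3-phenoxypropyl also separates from isopropyl beyond the scatter (a 2.2-fold higher number from compound 1 to compound 4 (0.35 log units; beyond the scatter)).

The compounds shown leave open how an amine or a carboxylic acid at the end of this chain would compare with the phenoxy-bearing chains. Nothing given here accounts for any of these steps.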